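Aryl substituent swap on the shared core

The source may hold more compounds than are shown below. What is called first, only, known or untested is meant among the compounds shown, and "the series" means these compounds.

Measured so far in an assay for binding affinity to dual specificity mitogen-activated protein kinase kinase 4 (Homo sapiens), read by KINOMEscan, tested at 100 nM; a higher number here means a weaker effect of the compound at the concentration tested, a lower number a stronger effect:
compound 1 `CCCS(=O)(=O)Nc1ccc(F)c(C(=O)c2n[nH]c3ncc(-c4ccc(OC)cc4)cc23)c1F`: compound 1 gives 4.2%
compound 2 `CCCS(=O)(=O)Nc1ccc(F)c(C(=O)c2n[nH]c3ncc(-c4ccc(O)cc4)cc23)c1F`: compound 2 gives 0.75%
compound 3 `CCCS(=O)(=O)Nc1ccc(F)c(C(=O)c2n[nH]c3ncc(-c4ccc(Cl)cc4Cl)cc23)c1F`: compound 3 gives 22%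

Compound 1 stands second highest of the three. Its nearest neighbour is compound 2, a number 3.5 percentage points lower from compound 1 to compound 2 (within the scatter), within the scatter; its furthest is compound 3, a number 17.8 percentage points higher from compound 1 to compound 3 (beyond the scatter), beyond it.

Compound 4 `CCCS(=O)(=O)Nc1ccc(F)c(C(=O)c2n[nH]c3ncc(-c4ccc(C(C)(C)C)cc4)cc23)c1F` differs from compound 1 by tert-butyl in place of methoxy on an aromatic carbon. For the measured compounds named here, no measured step makes this exact change. The step of a number 17.8 percentage points higher from compound 1 to compound 3 (beyond the scatter) altered the same aryl ring and gave a modest rise; the step of a number 21.3 percentage points higher from compound 2 to compound 3 (beyond the scatter) did likewise. The step of a number 3.5 percentage points lower from compound 1 to compound 2 (within the scatter) touched only the oxygen substituent and stayed within the scatter. A modest rise in this assay is therefore expected, a number 7.8 percentage points higher from compound 1 to compound 4 (within the scatter). Compound 4 is estimated at 12%, expected between 2% and 40%.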

Compound 4, a percentage reported as activity, at one concentration (the size of the read-out at that concentration, not a potency): 46%
Compound 4: the middle estimate sits 34 percentage points below what was measured, and the stated range ends below it.
By their numbers in this assay, from the lowest: compounds 2 and 1 (each within the scatter of the next); then compound 3; then compound 4.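

In this assay, the group on this aromatic carbon matters far more than the earlier methoxy-to-hydroxy step suggested: tert-butyl in place of methoxy gives a number 41.8 percentage points higher from compound 1 to compound 4 (beyond the scatter), and tert-butyl in place of hydroxy gives a number 45.3 percentage points higher from compound 2 to compound 4 (beyond the scatter). The 4-(tert-butyl)phenyl ring also weakens the effect relative to the 2,4-dichlorophenyl ring, a number 24 percentage points higher from compound 3 to compound 4 (beyond the scatter), so compound 3 did not mark the weak end of this aryl series. Nothing measured here accounts for this loss of effect.

As far as these compounds go, whether a smaller carbon group, such as methyl or ethyl, on this carbon behaves like tert-butyl or like methoxy remains open. So does whether an amine there would match the hydroxy of compound 2.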